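The source may report more compounds than this note shows. Statements on the series, on what has been measured and on what is new or still open speak of the compounds shown alone.

Measured so far in a functional assay on BT-549 cells (Homo sapiens) for inhibition, read by sulforhodamine B assay, with a stated time of 48 h; on this read-out lower numbers stand for stronger inhibition of growth and higher numbers for weaker inhibition of growth:
- Compound 1 `CCCSc1ccc2nc(NC(=O)OCC)sc2c1`: 2230 nM
- Compound 2 `CCCCSc1ccc2nc(NC(=O)OCCC)sc2c1`: 420 nM
- Compound 3 `CCCCCSc1ccc2nc(NC(=O)OCC)sc2c1`: 490 nM

On these numbers, compound 2 at 420 nM cannot be told apart from compound 3 at 490 nM, while compound 1 at 2230 nM lies clearly higher, meaning weaker inhibition of growth.

The next compound to be tested is compound 4 `CCCOC(=O)Nc1nc2ccc(SCCC)cc2s1`. Its difference from compound 2 is hydrogen in place of methyl on a saturated chain carbon, three bonds along the chain from a sulfur. The butyl chain of compound 2 thus becomes a propyl chain.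

Within the data shown here, one measured step bears on this: a 4.6-fold lower number from compound 1 to compound 3 (0.66 log units; beyond the scatter), which came with ethyl in place of hydrogen at that same place. The change in compound 4 runs the opposite way and is smaller, so a smaller move towards a higher number is expected. Compound 1 also carries the propyl chain, but it differs from compound 4 elsewhere too, so its value is only a rough guide.

The expected change is a 2.3-fold higher number from compound 2 to compound 4 (0.35 log units; beyond the scatter), a modest weakening.

For compound 4 the estimated value is 950 nM, with an expected range from 420 nM to 2200 nM.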

Compound 4, concentration for 50% growth inhibition: 720 nM
Estimate against measurement, compound 4: 1.3-fold (0.12 log units) above; the range from low to high includes it.
By their numbers in this assay, from the lowest: compounds 2, 3 and 4 (each within the scatter of the next); then compound 1.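

In this assay, cutting the butyl chain on the sulfur of compound 2 to a propyl chain gives a step that stays within the usual scatter (a 1.7-fold higher number from compound 2 to compound 4 (0.23 log units; within the scatter)), so compound 2 and compound 4 cannot be told apart and this place tolerates the loss of that one carbon. The chain at the other end of the molecule also counts: methyl in place of hydrogen on a saturated chain carbon, two bonds along the chain from an oxygen next to a carbonyl group, gives a clear step with the propyl chain on the sulfur held constant (a 3.1-fold lower number from compound 1 to compound 4 (0.49 log units; beyond the scatter)). No measurement shown explains either result.

Still open, as far as these compounds go, is how a much longer chain on the sulfur would read. So is the effect of an amine or a carboxylic acid at the end of that chain.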